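The source may hold more compounds than are shown below. What is called first, only, known or untested is meant among the compounds shown, and "the series" means these compounds.

Compound 1 `N#CC1=C(N)OC(c2c[nH]c3ccccc23)=C(C#N)C1c1ccccc1F`: "not active" (no number reported)
Compound 2 `N#CC1=C(N)OC(c2c[nH]c3ccccc23)=C(C#N)C1c1ccc2ccccc2c1`: "not active" (no number reported)
Compound 3 `COc1ccc(C2C(C#N)=C(N)OC(c3c[nH]c4ccccc34)=C2C#N)cc1OC`: 19.1%

Of the compounds shown here, three built on the same core have been tested in a functional assay, tested at 100 ug/mL; a higher number here means a stronger effect of the compound at the concentration tested, a lower number a weaker effect. Compound 1 and compound 2 are reported without a number, simply as not active. Within the data shown here, compound 3 gives 19.1% in this assay, and this is the only number in the whole set, so compound 3 stands alone as the one compound with a reported effect; there is nothing measured to rank it against.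

Compound 4 `CN(C)c1ccc(C2C(C#N)=C(N)OC(c3c[nH]c4ccccc34)=C2C#N)cc1` differs from compound 3 by 4-(dimethylamino)phenyl in place of 3,4-dimethoxyphenyl on a saturated ring carbon. Among the measured compounds shown here, no measured pair shows what such a change does here, so the size of the step can only be guessed from the fact that the one reported number is modest while the two other compounds give none. The step from compound 3 to compound 4 is expected to be a number 4.1 percentage points lower from compound 3 to compound 4 (within the scatter), that is, a change that stays within the usual scatter, if anything a slight fall. Compound 4 is therefore expected to give 15% in this assay, with a likely range from 4% to 30%.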

Compound 4, a percentage reported as activity, at one concentration (the size of the read-out at that concentration, not a potency): 18.5%
Compound 4: the middle estimate sits 3.5 percentage points below what was measured; low and high end bracket the measured number.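

Putting 4-(dimethylamino)phenyl in place of 3,4-dimethoxyphenyl on the saturated ring carbon gives a number 0.6 percentage points lower from compound 3 to compound 4 (within the scatter) in this assay and leaves the two compounds indistinguishable in this read-out. This position now has two numbers to set side by side, and they show that, in this pair, a reported effect of this size does not require the 3,4-dimethoxyphenyl group. Nothing shown accounts for this result.

Steps involving compound 1 and compound 2 cannot be read, as neither carries a number, so what separates a reported effect from none at this position stays open. Also open, going by these compounds, is whether a hydroxyl or a carboxylic acid on the phenyl ring, or a primary amine in place of the dimethylamino group, would give a number at all, or one clearly above these.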